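Cyclohexyl in place of tert-butyl on the urea nitrogen

A few compounds are considered here, and "the series" means these few. Any claim that something is new, unique, unknown or untested is made for them only; others in the source may bear on it.

Compound 2 `CC(C)(C)NC(=O)N1CCN(C(=S)SCc2cn(Cc3ccccc3F)nn2)CC1` is a thiocarbamate-linked urea. In a functional assay on SMMC-7721 cells (Homo sapiens) for cytotoxicity, read by MTT assay, with a stated time of 72 h (a lower number here means a stronger inhibitor, a higher number a weaker inhibitor), compound 2 gives > 128000 nM, which is a limit of the assay rather than a number. Compound 1 `NC(=O)N1CCN(C(=S)SCc2cn(Cc3ccccc3F)nn2)CC1` gives > 128000 nM in this assay, also a limit. The step that the two limits leave unreadable from compound 1 to compound 2 is therefore not readable, as the limit of > 128000 nM in this assay, at which 2 of the 2 values shown sit, shows. Compound 3 `O=C(NC1CCCCC1)N1CCN(C(=S)SCc2cn(Cc3ccccc3F)nn2)CC1` differs from compound 2 by cyclohexyl in place of tert-butyl on an amide-type nitrogen. Among the compounds with values here, no measured step bears on this change, and the only related step is unreadable. Compound 3 is expected to give 200000 nM, between 60000 nM and 600000 nM. The expected step that the limit leaves unreadable from compound 2 to compound 3 is none beyond the scatter.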

Compound 3, half-maximal inhibitory concentration: > 128000 nM
Compound 3: only a limit was reported; the forecaster's own chance of this, stated with the estimate: 85%; the middle value does not contradict the limit.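

No step from compound 1 or compound 2 to compound 3 can be read, as all three compounds sit at the same limit of the assay: the limit of > 128000 nM in this assay, at which 3 of the 3 values shown sit.

The compounds shown leave open whether any group on the amide-type nitrogen changes how strongly these compounds act on the cells.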